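Compound 3 to compound 4: acetamido becomes a carbamate

The source may hold more compounds than are shown below. What is called first, only, known or untested is meant among the compounds shown, and "the series" means these compounds.

In a functional assay on aorta (Rattus norvegicus, strain Sprague-Dawley) (a lower number here means that less compound is needed, a higher number that more compound is needed for the effect), compound 1 `Cc1nn(-c2ccccc2)c2nc(OCc3ccccc3F)c(-c3nc(N)cc(N)n3)cc12` gives 2200 nM, compound 2 `Cc1nn(-c2ccccc2)c2nc(OCc3ccccc3F)c(-c3nc(N)c(N4CCCC4)c(N)n3)cc12` gives 12700 nM, and compound 3 `CC(=O)Nc1c(N)nc(-c2cc3c(C)nn(-c4ccccc4)c3nc2OCc2ccccc2F)nc1N` gives 930 nM, the lowest of the three numbers. Compound 4 `Cc1nn(-c2ccccc2)c2nc(OCc3ccccc3F)c(-c3nc(N)c(NC(=O)OC4CCCC4)c(N)n3)cc12` has cyclopentyloxy in place of methyl on a carbonyl carbon, which turns acetamido into (cyclopentyloxycarbonyl)amino: cyclopentyloxy in place of methyl on a carbonyl carbon. Three measured steps offer indirect guidance. Acetamido in place of hydrogen gave a 2.4-fold lower number from compound 1 to compound 3 (0.37 log units; beyond the scatter), pyrrolidin-1-yl in place of hydrogen gave a 5.8-fold higher number from compound 1 to compound 2 (0.76 log units; beyond the scatter), and acetamido in place of pyrrolidin-1-yl gave a 14-fold lower number from compound 2 to compound 3 (1.14 log units; beyond the scatter). None of them tests this exact change, so only a modest move towards a higher number in this assay is expected, an estimated 2.2-fold higher number from compound 3 to compound 4 (0.33 log units; beyond the scatter). The estimate for compound 4 is 2000 nM, with an expected range of 500 nM to 8000 nM.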

Compound 4, half-maximal effective concentration: > 100000 nM
Compound 4: a limit, no number (the forecaster's own chance of this, stated with the estimate: 10%); middle value at least 50-fold (1.69 log units) away from the limit.
By their numbers in this assay, from the lowest: compound 3; then compound 1; then compound 2. At a limit, above all of these: compound 4.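

In this assay compound 4 gives > 100000 nM, which is a limit of the assay and not a number. On this carbonyl carbon, cyclopentyloxy in place of methyl gives an at least 100-fold higher number from compound 3 to compound 4 (2.03 log units; beyond the scatter), so the gain seen with acetamido does not carry over to every acylated amino group here. The new group also gives an at least 45-fold higher number from compound 1 to compound 4 (1.65 log units; beyond the scatter) and an at least 7.8-fold higher number from compound 2 to compound 4 (0.89 log units; beyond the scatter), which puts it above even the pyrrolidin-1-yl compound. The compounds shown leave open whether the added oxygen or the cyclopentyl ring drives this rise; a methyl carbamate or a cyclopentanecarboxamide would separate the two.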